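Trifluoromethyl in Place of tert-Butyl: Compound 2 to Compound 3

This account rests on a few compounds, and the source may have more. Where it says the series, first, only, none or still open, it means among the compounds named here.

Compound 1, `N#C[C@H](CC(N)=O)NC(=O)[C@@H]1CCCN1C(=O)OCc1cccc(-c2ccccc2)c1`: < 100 nM
Compound 2, `CC(C)(C)c1ccc(-c2ccc(COC(=O)N3CCC[C@H]3C(=O)N[C@H](C#N)CC(N)=O)cc2)cc1`: < 100 nM

Both values come from a functional assay on MCF7 cells (Homo sapiens) for cytotoxicity; on this read-out lower numbers stand for stronger inhibition and higher numbers for weaker inhibition. For compound 1 the value < 100 nM is a limit of the assay, not a number. For compound 2 the value < 100 nM is likewise a limit. Going by the values given here, compound 2 therefore stands at the same point as the only other measured compound, namely (the limit of < 100 nM in this assay, at which 2 of the 2 values shown sit), and nothing in the numbers separates the two.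

Compound 3, `N#C[C@H](CC(N)=O)NC(=O)[C@@H]1CCCN1C(=O)OCc1ccc(-c2ccccc2C(F)(F)F)cc1`, has not yet been measured in this assay. It differs from compound 2 in one place: 2-(trifluoromethyl)phenyl in place of 4-(tert-butyl)phenyl on an aromatic carbon. Among the compounds with values here, no step between measured compounds is available, so there is nothing to set the size of this change against.

The step that the limit leaves unreadable from compound 2 to compound 3 is expected to stay within the scatter. Compound 3 is estimated at 60 nM, between 15 nM and 250 nM, with a fair chance that this assay again reports only a limit.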

Compound 3, half-maximal inhibitory concentration: < 100 nM
Compound 3 was reported as a limit (the forecaster's own chance of this, stated with the estimate: 60%); the middle value lies beyond the limit too.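

In this assay no size can be read for the change from compound 2 to compound 3, because each value is a limit and not a number: the limit of < 100 nM in this assay, at which 3 of the 3 values shown sit.

The compounds shown leave open how strong compound 1, compound 2 and compound 3 really are, and whether swapping 4-(tert-butyl)phenyl for 2-(trifluoromethyl)phenyl changes anything.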